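The source may hold more compounds than are shown below. What is called first, only, known or untested is meant among the compounds shown, and "the series" means these compounds.

Values in a functional assay on HGC-27 cells (Homo sapiens) for antiproliferative activity, read by MTT assay, with stated times of 72 h and 4 h (on this read-out lower numbers stand for stronger inhibition and higher numbers for weaker inhibition), so far:
- compound 1 `COc1ncc(-c2cc3c(N4CC(C)OC(C)C4)ncnc3s2)cc1NS(=O)(=O)c1ccc(F)cc1F` gives 860 nM
- compound 2 `COc1ncc(-c2cc3c(N4CCC(OC)CC4)ncnc3s2)cc1NS(=O)(=O)c1ccc(F)cc1F` gives 280 nM
- compound 3 `COc1ncc(-c2cc3c(N4CC5CCCC5C4)ncnc3s2)cc1NS(=O)(=O)c1ccc(F)cc1F` gives 1900 nM

Compound 3 has the highest number of the three, 1900 nM. The next change leads to compound 4 `COc1ncc(-c2cc3c(N4CC5COCC5C4)ncnc3s2)cc1NS(=O)(=O)c1ccc(F)cc1F` and is a group of 8 heavy atoms (6 carbon, 1 nitrogen, 1 oxygen; 2 five-membered non-aromatic rings with 1 hetero atom each) in place of a group of 8 heavy atoms (7 carbon, 1 nitrogen; one five-membered non-aromatic ring of carbon only, one five-membered non-aromatic ring with 1 hetero atom), on an aromatic carbon. Within the data shown here, two measured steps bear on it, both modest and beyond the scatter: a 2.2-fold higher number from compound 1 to compound 3 (0.34 log units; beyond the scatter) and a 6.8-fold higher number from compound 2 to compound 3 (0.83 log units; beyond the scatter). Each arrives at the all-carbon second ring from a group containing oxygen. Neither is an exact match for the new change, so they guide direction and rough size only. A modest step to a lower number is expected in this assay. The expected step is a 2.4-fold lower number from compound 3 to compound 4 (0.38 log units; beyond the scatter). Compound 4 is estimated at 800 nM, with an expected range of 350 nM to 1800 nM.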

Compound 4, half-maximal inhibitory concentration: 300 nM
Estimate against measurement, compound 4: 2.7-fold (0.43 log units) above; measured number below the stated range.
By their numbers in this assay, from the lowest: compounds 2 and 4 (each within the scatter of the next); then compound 1; then compound 3.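

In this assay, putting oxygen into the second five-membered ring gives a 6.3-fold lower number from compound 3 to compound 4 (0.80 log units; beyond the scatter) with the ring count and size unchanged, so this position responds to a single ring-atom exchange. The oxygen-containing fused group shows a 1.1-fold higher number from compound 2 to compound 4 (0.03 log units; within the scatter) against 4-methoxypiperidin-1-yl and a 2.9-fold lower number from compound 1 to compound 4 (0.46 log units; beyond the scatter) against 2,6-dimethylmorpholin-4-yl in the same series, so oxygen-containing groups of quite different shape can reach similar numbers here. No supporting data bear on the reason for these steps.

Still open, as far as these compounds go, is whether a ring amine nitrogen in place of that oxygen would keep the number, and whether a hydroxyl in place of the methoxy on the piperidine would do the same.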